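The source may hold more compounds than are shown below. What is called first, only, known or untested is meant among the compounds shown, and "the series" means these compounds.

Measured compounds:
- compound 1, `COc1c(NS(=O)(=O)c2ccc(F)cc2)cc(-c2ccc3nc(NC4CC4)sc3n2)cc1C(N)=O`: 41700 nM
- compound 2, `COc1c(NS(=O)(=O)c2ccc(F)cc2)cc(-c2ccn3nc(NC(C)=O)nc3c2)cc1C(N)=O`: "not determined" (no result reported)
- compound 3, `COc1c(NS(=O)(=O)c2ccc(F)cc2)cc(-c2ccc3nc(NC(=O)C4CC4)nn3c2)cc1C(N)=O`: "not determined" (no result reported)

Compound 1 is the only one of the three with a number in a functional assay on U-87MG ATCC cells (Homo sapiens) for antiproliferative activity, read by MTT assay, with a stated time of 72 h; a lower number here means a stronger inhibitor, a higher number a weaker inhibitor; compounds 2 and 3, which carry different cores, were left without a result, so nothing can be said about how they compare. Compound 1 stands alone at the weak end, with an inhibitor that needs a high concentration. Among the compounds with values here, compound 4, `COc1c(NS(=O)(=O)c2ccc(F)cc2)cc(-c2ccc3nc(NC(C)=O)sc3n2)cc1C(N)=O`, keeps the shared core and changes only one group: acetyl in place of cyclopropyl on a nitrogen on an aromatic ring. Within the data shown here, no comparison between measured compounds is available to anchor this change. The expected step of a 1.1-fold higher number from compound 1 to compound 4 (0.03 log units; within the scatter) is therefore none beyond the scatter, in either direction. Compound 4 is expected to give about 45000 nM, in a range from 15000 nM to 120000 nM.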

Compound 4, half-maximal inhibitory concentration: 21700 nM
Estimate against measurement, compound 4: 2.1-fold (0.32 log units) above; low and high end bracket the measured number.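

In this assay, within the data shown here, acetyl in place of cyclopropyl on this nitrogen gives a 1.9-fold lower number from compound 1 to compound 4 (0.28 log units; within the scatter), which offers the first reading of this position. A three-membered carbon ring and an acetyl group with one hydrogen-bond acceptor cannot be told apart here, so this swap does not change the activity in any meaningful way. Nothing available explains this result.

On these data alone, whether a free amine, a longer chain or a carboxylic acid on this nitrogen would move the number beyond the scatter stays open. How much the core matters also stays open: the other cores shown carry no number.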